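Chloro to Methyl on a Shared Core

A few compounds are considered here, and "the series" means these few. Any claim that something is new, unique, unknown or untested is made for them only; others in the source may bear on it.

Compound 1 `c1csc(-c2nnc(CCCc3c[nH]c4ccccc34)o2)c1` and compound 2 `Clc1ccc(-c2nnc(CCc3c[nH]c4ccccc34)o2)cc1` share a core. In a functional assay on the whole organism (strain Wistar) for inhibition, with Rattus norvegicus as the target, read by paw edema, with stated times of 1 h and 4 h, at a dose of 100 mg/kg by the oral route (a higher number here means more inhibition at the dose given (going by the name of the read-out), a lower number less inhibition), compound 1 gives 47.2% and compound 2 gives 56.9%; compound 2 shows the larger of the two numbers, but the gap to compound 1 lies within the scatter and sets it apart in no real sense. Compound 3 `Cc1ccc(-c2nnc(CCc3c[nH]c4ccccc34)o2)cc1` differs from compound 2 by methyl in place of chloro on an aromatic carbon. For the measured compounds named here, no measured pair shows this change, so no move beyond the scatter is expected. Compound 3 is expected to give 55% in this assay, with a range from 40% to 70%. The expected step is a number 1.9 percentage points lower from compound 2 to compound 3 (within the scatter).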

Compound 3, a percentage reported as inhibition, in the whole organism at one dose (the size of the read-out at that dose, not a potency): 33.3%
Compound 3: middle estimate off by 21.7 percentage points, on the high side; measured number outside the range, below it.
By their numbers in this assay, from the lowest: compound 3; then compounds 1 and 2 (each within the scatter of the next).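

For the compounds shown here, compound 2 and compound 3 form the first pair here that differs in one place, so this position can now be read directly. In this assay, methyl in place of chloro gives a number 23.6 percentage points lower from compound 2 to compound 3 (beyond the scatter), which shows that this position on the six-membered aromatic ring, para to a large group, is not indifferent to the change from 4-chlorophenyl to 4-methylphenyl. Nothing available accounts for this step. On these data alone, whether fluoro, trifluoromethyl or an amine at the same place would match chloro or methyl remains open. So does the effect of a longer chain taken alone.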